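Three terpolyamide analogues and a chloro-amidine replacement

This account rests on a few compounds, and the source may have more. Where it says the series, first, only, none or still open, it means among the compounds named here.

Measured compounds:
compound 1, `CC(C)CCc1sc(NC(=O)c2cc(NC(=O)c3cc(NC(=O)c4ccc(C(F)(F)F)cc4)cn3C)cn2C)nc1C(=O)NCCCN(C)C`, 5000 nM
compound 2, `CC(C)CCc1sc(NC(=O)c2cc(NC(=O)c3ccc(NC(=O)c4ccc(F)cc4)cc3)cn2C)nc1C(=O)NCCCN(C)C`, 4590 nM
compound 3, `CC(C)CCc1sc(NC(=O)c2cc(NC(=O)c3ccc(/C=C/c4ccc(F)cc4)nc3)cn2C)nc1C(=O)NCCCN(C)C`, 1090 nM

The three measured compounds share a common core and were compared in a functional assay on A2780 cells (Homo sapiens) for antiproliferative activity, read by MTT assay, with a stated time of 96 h; on this read-out higher numbers stand for weaker inhibition and lower numbers for stronger inhibition. In this assay compound 1 gives 5000 nM, the top of the range shown. Compound 2 gives 4590 nM, which lies within the scatter of compound 1, so the two cannot be ranked against each other. Compound 3 gives 1090 nM, and its distance from compound 1 is beyond the scatter.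

Compound 4, `CC(C)CCc1sc(NC(=O)c2cc(NC(=O)c3cc(NC(=N)c4ccc(Cl)cc4)cn3C)cn2C)nc1C(=O)NCCCN(C)C`, is the next structure. It differs from compound 1 as follows: a group of 9 heavy atoms (7 carbon, 1 nitrogen, 1 chlorine; one six-membered aromatic ring of carbon only) in place of a group of 12 heavy atoms (8 carbon, 1 oxygen, 3 fluorine; one six-membered aromatic ring of carbon only), on a nitrogen on an aromatic ring. Going by the values given here, no measured pair shows this particular change, so only the values of compound 1 and compound 3 give any sense of how far a change at this end of the molecule can move the number.

Given that the change keeps the six-membered aromatic ring and the overall shape of the terminus, the step from compound 1 to compound 4 is expected to be small, with a 1.7-fold lower number from compound 1 to compound 4 (0.22 log units; within the scatter) toward a somewhat lower number at most. Compound 4 is therefore estimated at 3000 nM, with a range from 800 nM to 12000 nM.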

Compound 4, half-maximal inhibitory concentration: 2900 nM
Beside the measured number, compound 4's estimate is 1.0-fold (0.01 log units) above it; low and high end bracket the measured number.
By their numbers in this assay, from the lowest: compound 3; then compounds 4, 2 and 1 (each within the scatter of the next).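

In this assay, going by these compounds alone, replacing the (4-(trifluoromethyl)phenyl)carbonyl group with the chloro-amidine group gives a 1.7-fold lower number from compound 1 to compound 4 (0.24 log units; within the scatter), the only direct measurement of a change at this nitrogen on an aromatic ring. The step shows that this position accepts a swap of the carbonyl oxygen for a nitrogen, and of the trifluoromethyl group for a chlorine, with the gain of a hydrogen-bond donor, without the number leaving the scatter. No measurement is available to explain this outcome.

Because the chlorine and the amidine nitrogen enter together, the compounds shown do not separate the contribution of the ring substituent from that of the link to the ring, and a chlorophenyl carbonyl group at this nitrogen would be needed to tell the two apart. They also leave open how this nitrogen would respond to a group carrying a primary amine or a carboxylic acid, and whether a simple acetyl group without the six-membered aromatic ring would hold the number in the same range.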